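Extending the amide side chain from methyl to benzyl

The source may hold more compounds than are shown below. What is called first, only, known or untested is meant among the compounds shown, and "the series" means these compounds.

In a functional assay on A549 cells (Homo sapiens) for cytotoxicity, read by MTT assay, with a stated time of 48 h (a lower number here means a stronger inhibitor, a higher number a weaker inhibitor), compound 1 (`CNC(=O)CC[C@H](NS(=O)(=O)c1ccc([N+](=O)[O-])cc1)C(=O)O`) gives > 500000 nM as its reading, and this is a limit of the assay, not a number. Compound 1 therefore stands at the limit of > 500000 nM in this assay, at which 1 of the 2 values shown sits, and offers no exact starting point. Compound 2 (`CCCCNC(=O)CC[C@H](NS(=O)(=O)c1ccc([N+](=O)[O-])cc1)C(=O)O`) gives 276000 nM in this assay with propyl in place of hydrogen on a saturated chain carbon bound to an amide-type nitrogen. Compound 3 (`O=C(CC[C@H](NS(=O)(=O)c1ccc([N+](=O)[O-])cc1)C(=O)O)NCc1ccccc1`) instead carries phenyl in place of hydrogen on a saturated chain carbon bound to an amide-type nitrogen, a change that also reads methyl to benzyl. For the measured compounds named here, the one measured step that bears on this change is an at least 1.8-fold lower number from compound 1 to compound 2 (0.25 log units; that floor lies within the scatter) (made at the same place), and its true size stays open. Going by the values given here, with compound 2 at 276000 nM as the only numbered neighbour, a modest move toward a lower number in this assay is expected, perhaps not beyond the scatter. The expected step is an at least 2.2-fold lower number from compound 1 to compound 3 (0.35 log units; beyond the scatter) (an estimate). Compound 3 is estimated at 220000 nM (expected range 90000 nM to 500000 nM).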

Compound 3, half-maximal inhibitory concentration: 343000 nM
Beside the measured number, compound 3's estimate is 1.6-fold (0.19 log units) below it; measured number inside the range.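

Swapping propyl for phenyl at this place makes no difference that can be read, as a 1.2-fold higher number from compound 2 to compound 3 (0.09 log units; within the scatter) shows in this assay, so a six-membered aromatic ring of carbon and a saturated chain cannot be told apart here, which compound 2 alone could not show. Measured against the methyl amide, the new compound gives only a floor, an at least 1.4-fold lower number from compound 1 to compound 3 (0.16 log units; that floor lies within the scatter), so a second numbered compound still does not establish that either longer side chain truly lowers the number. Compound 1 remains a limit of the assay and not a number, so the true size of both steps starting from it cannot be read: the limit of > 500000 nM in this assay, at which 1 of the 3 values shown sits.

Whether an amine or a carboxylic acid at the end of the side chain, or a chain longer than those shown, would move the reading beyond the scatter stays open. Also open, on these data alone, is whether a substituted phenyl in place of the plain one would separate itself from the propyl chain at this place, and how much any change here can do on the shared core.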